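The source may report more compounds than this note shows. Statements on the series, on what has been measured and on what is new or still open speak of the compounds shown alone.

Measured so far:
- compound 1, `CC(=O)N[C@@H]1CCCc2c1cncc2N1CCc2cc(Cl)ccc2C1=O`: 3920 nM
- compound 2, `CC(=O)N[C@H]1CCCc2c1cncc2N1Cc2cc(Cl)ccc2C1=O`: 39600 nM

In an ADME assay on cells for inhibition of cytochrome P450 11B1, mitochondrial (Homo sapiens), read by HTRF (on this read-out higher numbers stand for weaker inhibition and lower numbers for stronger inhibition), compound 1 gives 3920 nM. In this assay compound 2 gives 39600 nM, a number that is higher than that of compound 1 by a gap beyond the usual scatter, so compound 1 stands as the lower of the two numbers shown. Compound 2 also differs from compound 1 in more than one place, so its value says little about any single change.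

Compound 3, `CS(=O)(=O)N[C@@H]1CCCc2c1cncc2N1CCc2cc(Cl)ccc2C1=O`, has not been measured in this assay. It differs from compound 1 in one place: methylsulfonyl in place of acetyl on an amine nitrogen. Within the data shown here, no measured pair shows the effect of this exchange, so the expectation rests on compound 1 alone. The step of a 1.1-fold higher number from compound 1 to compound 3 (0.06 log units; within the scatter) is expected to stay within the scatter, in no clear direction. For compound 3 the estimate in this assay is 4500 nM, within a range of 1500 nM to 15000 nM.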

Compound 3, half-maximal inhibitory concentration: 5150 nM
Compound 3: middle estimate off by 1.1-fold (0.06 log units), on the low side; measured number inside the range.
By their numbers in this assay, from the lowest: compounds 1 and 3 (each within the scatter of the next); then compound 2.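

On the amine nitrogen of the shared core, methylsulfonyl can take the place of acetyl with little effect on the number in this assay, with a 1.3-fold higher number from compound 1 to compound 3 (0.12 log units; within the scatter). Among these compounds, compounds 1 and 3 are the first pair here that differ in only one place, so this result speaks directly to the exchange of acetamido for methanesulfonamido, which compound 2 could not do. No other data shown explain why the two groups give numbers within the scatter of each other.

As far as these compounds go, it remains open whether a free amine, a urea or a longer chain such as butanoyl on this nitrogen would shift the number beyond the scatter. Compound 2 differs from compound 1 in more than one place, so the contribution of each of those differences also stays unresolved.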